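The source may hold more compounds than are shown below. What is called first, only, known or untested is meant among the compounds shown, and "the series" means these compounds.

Measured so far in a functional assay on MCF7 cells (Homo sapiens) for cytotoxicity, read by MTT assay, with a stated time of 48 h; on this read-out higher numbers stand for weaker inhibition and lower numbers for stronger inhibition:

compound 1 `C/C(=N\NC(=S)Nc1ccccc1I)c1ccccn1` gives 4.1 nM
compound 2 `C/C(=N/NC(=S)Nc1ccccc1)c1ccccn1` gives 0.18 nM
compound 3 `CC(=NNC(=S)Nc1ccccc1)c1ccccn1` gives 0.18 nM

Compound 3 stands level with compound 2 at the digits reported, and together they hold the lowest of the three numbers. Compound 1 lies well above both, beyond the scatter. Compound 4 `C/C(=N\NC(=S)Nc1ccccc1)c1ccccn1` has yet to be measured.

The change is the two compounds have the same atoms and bonds; at least one stereo element is drawn with a configuration in one of them and without one in the other: 1 of 1 stereo elements differ; a double bond is drawn without a configuration in compound 3 and E in compound 4, so a double bond is drawn without a configuration in compound 3 and E in compound 4. Nothing else differs.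

One measured step is of the same kind, a difference in drawn configuration alone. It is no change at the digits printed from compound 2 to compound 3 (within the scatter), which shows no movement within the scatter. With that single step as the guide, no shift in either direction is expected in this assay beyond the scatter. The expected step is a 1.1-fold higher number from compound 3 to compound 4 (0.05 log units; within the scatter).

For compound 4 the estimated value is 0.2 nM, with an expected range from 0.08 nM to 0.8 nM.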

Compound 4, half-maximal inhibitory concentration: 0.18 nM
The estimate for compound 4 lay 1.1-fold (0.05 log units) above the measured number, and the stated range covers the measured number.
By their numbers in this assay, from the lowest: compounds 2, 3 and 4 (each within the scatter of the next); then compound 1.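

In this assay the E drawing now joins the other two, with no change at the digits printed from compound 3 to compound 4 (within the scatter) and no change at the digits printed from compound 2 to compound 4 (within the scatter), so no drawn form of this double bond stands apart from the others. The earlier compounds shown here offered only a comparison with an undefined drawing, whereas this result adds a comparison of two defined configurations: the fact that compounds 2 and 4 differ only in the configuration as drawn. Among the compounds shown here, it also gives the first comparison in which the aromatic ring is the only place that differs, and a 23-fold lower number from compound 1 to compound 4 (1.36 log units; beyond the scatter) shows that hydrogen in place of iodo carries a step beyond the scatter.

The compounds shown leave open whether the higher number belongs to iodo alone or would also appear with fluoro, chloro, methyl or methoxy on that aromatic carbon. They also leave open whether compounds 2, 3 and 4 remain distinct forms under the assay conditions.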